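Extending the Hydroxycarbamoyl Chain Past an Assay Limit

This account rests on a few compounds, and the source may have more. Where it says the series, first, only, none or still open, it means among the compounds named here.

In a functional assay on PLC-PRF-5 cells (Homo sapiens) for inhibition, read by MTT assay, with a stated time of 72 h (a lower number here means a stronger inhibitor, a higher number a weaker inhibitor), compound 1 `Nc1nc2cc(-c3nn(CCCCC(=O)NO)c4ncnc(N)c34)ccc2o1` gives 29600 nM. Compound 2 `Nc1nc2cc(-c3nn(CCCCCC(=O)NO)c4ncnc(N)c34)ccc2o1` gives > 50000 nM, which is a limit of the assay and not a number. Its standing is therefore fixed only by the limit of > 50000 nM in this assay, at which 1 of the 2 values shown sits.

Compound 3 `Nc1nc2cc(-c3nn(CCCCCCCCC(=O)NO)c4ncnc(N)c34)ccc2o1` has not yet been measured. Its difference from compound 2 is 3-(hydroxycarbamoyl)propyl in place of hydroxycarbamoyl on a saturated chain carbon, five bonds along the chain from an aromatic nitrogen, with 3-(hydroxycarbamoyl)propyl in place of hydroxycarbamoyl on a saturated chain carbon, five bonds along the chain from an aromatic nitrogen.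

Going by the values given here, only one measured step bears on this change, the shorter chain extension an at least 1.6-fold higher number from compound 1 to compound 2 (0.22 log units; that floor lies within the scatter). That step is a floor, and it gives neither a firm size nor a firm direction. A single step also cannot simply be carried over to a longer chain. As far as these compounds go, no step beyond the scatter is therefore expected in this assay, and the direction remains open.

The estimated step is an at least 1.4-fold lower number from compound 2 to compound 3 (0.15 log units; that floor lies within the scatter). Compound 3 is expected at 35000 nM, with an estimated range of 6000 nM to 60000 nM.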

Compound 3, half-maximal inhibitory concentration: 24000 nM
For compound 3 the middle estimate is 1.5-fold (0.16 log units) above the measured one; the measured number falls inside the stated range.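

In this assay, going by these compounds alone, 3-(hydroxycarbamoyl)propyl in place of hydroxycarbamoyl, on a saturated chain carbon, five bonds along the chain from an aromatic nitrogen, gives an at least 2.0-fold lower number from compound 2 to compound 3 (0.31 log units; beyond the scatter), the first step at this position to lie beyond the scatter, and it runs opposite to what the floor of the shorter extension might have suggested. Set against the shorter chain, the same lengthening gives a 1.2-fold lower number from compound 1 to compound 3 (0.09 log units; within the scatter), so the two ends of this short series cannot be told apart, and added chain length alone does not move the number in one steady direction across compound 1, compound 2 and compound 3. For compound 2 the reading is a limit of the assay and not a number, so the step that leaves it gives a floor and no firm size: the limit of > 50000 nM in this assay, at which 1 of the 3 values shown sits.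

The compounds shown leave open where compound 2 truly stands and whether a still longer chain would continue the fall seen at compound 3 or reverse it. They also leave open what a carboxylic acid or a primary amide in place of the hydroxycarbamoyl end would do at any of these chain lengths.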